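The source may hold more compounds than are shown below. What is called first, only, known or untested is meant among the compounds shown, and "the series" means these compounds.

Working notes on the series.

In a functional assay on CHO cells for antagonist activity at metabotropic glutamate receptor 7 (Rattus norvegicus), read by FLIPR and calcium flux (a lower number here means a stronger inhibitor, a higher number a weaker inhibitor), compound 3 `COc1ccc(-c2cc3onc(-c4ccccc4)c3c(=O)n2C)cc1` gives 22 nM, the lowest of the two numbers available in the set. Compound 2 `Cn1c(-c2ccccc2)cc2onc(-c3cccnc3)c2c1=O` gives 240 nM in this assay, a higher number than compound 3 and a gap beyond the scatter. For compound 1 `CC(C)n1c(-c2ccccc2)cc2onc(-c3ccccc3)c2c1=O` this assay reports only > 10000 nM; this is a limit of the assay and not a number, namely (the limit of > 10000 nM in this assay, at which 1 of the 3 values shown sits).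

Compound 4 `CCCc1ccc(-c2cc3onc(-c4ccccc4)c3c(=O)n2C)cc1` differs from compound 3 in one place: propyl in place of methoxy on an aromatic carbon. Going by the values given here, no pair of measured compounds in the set is separated by this change alone, so the size of the step cannot be read from a measured step and rests on judgment only. In this assay a modest weakening is expected from compound 3 to compound 4, with a size that may stay within the scatter: a 2.3-fold higher number from compound 3 to compound 4 (0.36 log units; beyond the scatter). For compound 4 the estimated value in this assay is 50 nM, with an expected range from 12 nM to 250 nM.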

Compound 4, half-maximal inhibitory concentration: 150 nM
The estimate for compound 4 lay 3.0-fold (0.48 log units) below the measured number, within the range that was stated.
By their numbers in this assay, from the lowest: compound 3; then compounds 4 and 2 (each within the scatter of the next). At a limit, above all of these: compound 1.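

Going by these compounds alone, this is the first measured step at this place, on an aromatic carbon para to a large group, as no earlier pair of compounds isolated it. In this assay, propyl in place of methoxy gives a 6.8-fold higher number from compound 3 to compound 4 (0.83 log units; beyond the scatter) and so shows that this position responds to the change, which removes the oxygen with its hydrogen-bond acceptor and adds carbon. No measurement in hand bears on the cause of this step.

A single step does not separate the loss of the oxygen from the change of chain, and ethoxy, ethyl or a hydroxyl group at this place would bear on that question. Also open, on these data alone, is how this position would respond to an amine or a carboxylic acid.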